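From a Formyl Group to a Naphthyl Ring

This account rests on a few compounds, and the source may have more. Where it says the series, first, only, none or still open, it means among the compounds named here.

Measured in a functional assay on OVCAR-8 cells (Homo sapiens) for inhibition, read by sulforhodamine B assay, with a stated time of 48 h, tested at 10 uM; on this read-out lower numbers stand for less inhibition and higher numbers for more inhibition at the one concentration tested (going by the name of the read-out):
- compound 1 `CCc1ccc(-c2cn3ccnc3c(-c3ccc4ncn(Cc5ccccc5)c4c3)n2)cc1`: 30.8%
- compound 2 `O=Cc1ccc(-c2cn3ccnc3c(-c3ccc4ncn(Cc5ccccc5)c4c3)n2)cc1`: 44%

Compound 2 stands highest of these two numbers, with compound 1 nearest. Among the measured compounds shown here, the one measured step, a number 13.2 percentage points higher from compound 1 to compound 2 (beyond the scatter), was modest and beyond the scatter. Compound 3 `c1ccc(Cn2cnc3ccc(-c4nc(-c5cccc6ccccc56)cn5ccnc45)cc32)cc1` differs from compound 2 by naphthalen-1-yl in place of 4-formylphenyl on an aromatic carbon. That step bears on the change only loosely, since it concerned swapping ethyl for formyl, whereas here the formyl group leaves and a naphthyl ring enters. As compound 3, like compound 1, lacks the formyl group, a modest downward step a number 11 percentage points lower from compound 2 to compound 3 (beyond the scatter) is expected. Compound 3 is estimated at 33%, within 15% to 52%.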

Compound 3, a percentage reported as inhibition, at one concentration (the size of the read-out at that concentration, not a potency): 6.22%
Beside the measured number, compound 3's estimate is 26.8 percentage points above it; the measured number lies below the stated range.
By their numbers in this assay, from the lowest: compound 3; then compound 1; then compound 2.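

In this assay, this position on the shared core proves sensitive to the group it carries: naphthalen-1-yl in place of 4-formylphenyl gives a number 37.8 percentage points lower from compound 2 to compound 3 (beyond the scatter), and naphthalen-1-yl in place of 4-ethylphenyl gives a number 24.6 percentage points lower from compound 1 to compound 3 (beyond the scatter). Loss of the formyl group alone does not account for the result, since compound 1 also lacks it and still stands above compound 3. Nothing measured here explains the fall.

Left open is how a plain phenyl ring, or a phenyl ring carrying an amine or a carboxylic acid, would compare at this position.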